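Compound 4: methyl on the hydroxyethyl amide

This account rests on a few compounds, and the source may have more. Where it says the series, first, only, none or still open, it means among the compounds named here.

Compound 1 `CNC(=O)c1cc(C(=O)NCCO)n([C@@H](C)c2ccccc2)n1`: >= 139 ug/mL (a limit)
Compound 2 `CNC(=O)c1cc(C(=O)N[C@H]2CC[C@H](OC)CC2)c([C@@H](C)c2ccccc2)o1`: >= 192 ug/mL (a limit)
Compound 3 `CNC(=O)c1cc(C(=O)N[C@H]2[C@@H]3C[C@@H](O)C[C@@H]32)c([C@@H](C)c2ccccc2)o1`: >= 172 ug/mL (a limit)

In a physicochemical assay for solubility (on this read-out lower numbers stand for lower solubility and higher numbers for higher solubility), compound 1 gives >= 139 ug/mL, which is a limit and not a number. All three measured compounds stand at limits, so compound 1 has no exact place among them.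

Compound 4 `CNC(=O)c1cc(C(=O)NC(C)CO)n([C@@H](C)c2ccccc2)n1` differs from compound 1 by methyl in place of hydrogen on a saturated chain carbon bound to an amide-type nitrogen and a saturated chain carbon. In words, this is methyl in place of hydrogen on a saturated chain carbon bound to an amide-type nitrogen and a saturated chain carbon, which turns 2-hydroxyethyl to 1-(hydroxymethyl)ethyl.

Among the measured compounds shown here, only one measured step is available, and it is a step that the two limits leave unreadable from compound 2 to compound 3. That step exchanges a different group on an amide-type nitrogen, and it offers no size to carry over. For the measured compounds named here, no measured step covers methyl in place of hydrogen.

With nothing to size the change, no shift beyond the usual scatter is expected in this assay, and no direction can be favoured. The expected change is a step that the limit leaves unreadable from compound 1 to compound 4. The reading may well be a limit again, as it is for all three measured compounds. For compound 4 the estimated value is 150 ug/mL, with an expected range of 80 ug/mL to 260 ug/mL.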

Compound 4, solubility: >= 132 ug/mL
Compound 4: no number, only a limit (the forecaster's own chance of this, stated with the estimate: 70%); the middle value lies beyond the limit too.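

In this assay compound 4 gives >= 132 ug/mL, which is a limit and not a number. Among the compounds shown here, compound 1 also stands at a limit, so no step from compound 1 to compound 4 can be read. Whether methyl in place of hydrogen on this saturated chain carbon changes the read-out at all stays open, as all four compounds shown stand at limits.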